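Benzylsulfanyl halogen exchange in a vasorelaxant amide series

This account rests on a few compounds, and the source may have more. Where it says the series, first, only, none or still open, it means among the compounds named here.

Measured compounds:
compound 1 `CC1=C(C(=O)Nc2ccc([N+](=O)[O-])cc2)C(c2cccc([N+](=O)[O-])c2)N=C(SCc2ccccc2)N1` — 17.5%
compound 2 `CC1=C(C(=O)Nc2ccc([N+](=O)[O-])cc2)C(c2cccc([N+](=O)[O-])c2)N=C(SCc2ccc(Cl)cc2)N1` — 15.5%

In a functional assay on the whole organism (artery, strain albino) with Rattus norvegicus as the target, with a stated time of 720 min, at a dose of 10 mg/kg by the oral route (a higher number here means more inhibition at the dose given (going by the name of the read-out), a lower number less inhibition), compound 1 gives 17.5% and compound 2 gives 15.5%. Of the two numbers, compound 2 holds the smaller one, although the gap to compound 1 is within the scatter. Compound 3 `CC1=C(C(=O)Nc2ccc([N+](=O)[O-])cc2)C(c2cccc([N+](=O)[O-])c2)N=C(SCc2ccc(F)cc2)N1` carries fluoro in place of chloro on an aromatic carbon. For the measured compounds named here, the only measured step touching this aromatic carbon, a number 2 percentage points lower from compound 1 to compound 2 (within the scatter), stayed within the scatter, so a second halogen exchange at the same place is expected to shift this assay no further than the scatter, with an expected step of a number 0.5 percentage points higher from compound 2 to compound 3 (within the scatter). Compound 3 is therefore estimated at 16%, within 6% to 26%.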

Compound 3, a percentage reported as inhibition, in the whole organism at one dose (the size of the read-out at that dose, not a potency): 20.1%
Compound 3: the middle estimate sits 4.1 percentage points below what was measured; the range from low to high includes it.
By their numbers in this assay, from the lowest: compounds 2, 1 and 3 (each within the scatter of the next).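

In this assay, fluoro in place of chloro on this aromatic carbon, para to a large group, gives a number 4.6 percentage points higher from compound 2 to compound 3 (within the scatter), and fluoro in place of hydrogen gives a number 2.6 percentage points higher from compound 1 to compound 3 (within the scatter). Hydrogen, chloro and fluoro at this place therefore cannot be told apart, so neither halogen exchange separates the compounds here. Nothing available bears on a cause for this result.

On these data alone, whether a different kind of group on this carbon, such as an amine, a carboxylic acid or a methoxy group, would move the read-out beyond the scatter remains open.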